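The source may hold more compounds than are shown below. What is called first, only, known or untested is meant among the compounds shown, and "the series" means these compounds.

In a functional assay on A-375 cells (Homo sapiens) for antiproliferative activity, read by CCK-8 assay, with a stated time of 72 h, tested at 8 uM (on this read-out higher numbers stand for a stronger effect at the one concentration tested and lower numbers for a weaker effect), compound 1 `Nc1ccccc1NC(=O)c1ccc(CSC(=S)N2CCN(c3ccccc3)CC2)cc1` gives 88.6%, compound 2 `Nc1ccccc1NC(=O)c1ccc(CSC(=S)N2CCCc3ccccc32)cc1` gives 81.5%, and compound 3 `N#Cc1ccc(N2CCN(C(=S)SCc3ccc(C(=O)Nc4ccccc4N)cc3)CC2)cc1` gives 62.9%. Compound 2 stands second highest of the three numbers: its nearest neighbour is compound 1, within the scatter, and its furthest is compound 3, beyond it. Going by the values given here, the only step between measured compounds that differ in one place is a number 25.7 percentage points lower from compound 1 to compound 3 (beyond the scatter), a modest fall.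

Compound 4 `CCN(Cc1ccncc1)C(=S)SCc1ccc(C(=O)Nc2ccccc2N)cc1` differs from compound 2 in one place: ethyl((pyridin-4-yl)methyl)amino in place of 1,2,3,4-tetrahydroquinolin-1-yl on a thiocarbonyl carbon. Among the compounds with values here, no measured step bears directly on this change; the step of a number 25.7 percentage points lower from compound 1 to compound 3 (beyond the scatter) concerns a different position and a different kind of group, so it offers no guide to the size expected here. The two measured groups on the thiocarbonyl carbon, in compound 1 and compound 2, give numbers within the scatter of each other, so a step no larger than the scatter is expected, with a wide range to allow for the unknown. Compound 4 is therefore estimated at 75%, between 55% and 90%. That estimate means an expected step of a number 6.5 percentage points lower from compound 2 to compound 4 (within the scatter).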

Compound 4, a percentage reported as inhibition, at one concentration (the size of the read-out at that concentration, not a potency): 86.2%
Estimate against measurement, compound 4: 11.2 percentage points below; low and high end bracket the measured number.
By their numbers in this assay, from the lowest: compound 3; then compounds 2, 4 and 1 (each within the scatter of the next).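

In this assay the change on the thiocarbonyl carbon amounts to a number 4.7 percentage points higher from compound 2 to compound 4 (within the scatter) and so leaves the read-out where it was. Going by these compounds alone, this shows that the position accepts more than the cyclic amines of the earlier compounds: ethyl((pyridin-4-yl)methyl)amino carries an open ethyl chain and a pyridine ring, has the same number of heavy atoms as 1,2,3,4-tetrahydroquinolin-1-yl, and adds a hydrogen-bond acceptor, without a step beyond the scatter. Nothing measured here accounts for this result.

The compounds shown leave open whether a carboxylic acid on the pyridine ring, or a longer chain such as n-hexyl in place of ethyl, would keep the number at this level. A single concentration also leaves open whether compound 2 and compound 4 differ in potency.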